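The compounds below may be only part of what the source reports. "The series", "measured", "known", "first", "only" and "open" are said of these compounds alone.

Compound 1 `CC(C)C(NC(=O)NO)C(=O)NC1CCCCC1`: in a functional assay on SW-620 cells (Homo sapiens) for inhibition (on this read-out higher numbers stand for weaker inhibition and lower numbers for stronger inhibition), compound 1 gives > 100000 nM.
Compound 2 `CCC(C)C(NC(=O)NO)C(=O)NC1CCCCC1`: compound 2 gives > 100000 nM.
Compound 3 `CCC(C)C(NC(=O)NO)C(=O)NC(c1ccccc1)c1ccccc1`: compound 3 gives >= 100000 nM.

The value of compound 1 is a limit of the assay, not a number. The same holds for compound 2. Compound 3 also rests at a limit, namely (the limit of >= 100000 nM in this assay, at which 1 of the 3 values shown sits), so its standing among the measured values is only a bound. Compound 4 `CCC(C)C(NC(=O)n1nnc2ccccc21)C(=O)NC(c1ccccc1)c1ccccc1` differs from compound 3 in one place: a group of 9 heavy atoms (6 carbon, 3 nitrogen; one five-membered aromatic ring with 3 hetero atoms, one six-membered aromatic ring of carbon only) in place of a group of 2 heavy atoms (1 nitrogen, 1 oxygen; no ring), on a carbonyl carbon. Going by the values given here, the only measured step, a step that the two limits leave unreadable from compound 1 to compound 2, touches a different part of the shared core and cannot be read because both of its ends sit at the limit of > 100000 nM in this assay, at which 2 of the 3 values shown sit. Among the compounds with values here, no measured step therefore bears on the change from compound 3 to compound 4, and neither size nor direction can be drawn from the data. Compound 4 is estimated at 80000 nM, within 10000 nM to 300000 nM. The step this estimate implies is an at least 1.2-fold lower number from compound 3 to compound 4 (0.09 log units; that floor lies within the scatter).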

Compound 4, half-maximal inhibitory concentration: 63500 nM
Beside the measured number, compound 4's estimate is 1.3-fold (0.10 log units) above it; the range from low to high includes it.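

Compound 4 is the only compound shown whose reading in this assay is a number and not a limit, so a change on this carbonyl carbon gives a value that can be placed. Compound 3 gives >= 100000 nM, which is a limit. The group of 9 heavy atoms in place of hydroxyamino gives an at least 1.5-fold lower number from compound 3 to compound 4 (0.19 log units; that floor lies within the scatter), so a measured value here does not need hydroxyamino, though that floor does not settle the size of the change.

From the compounds shown here alone, how an amine or a carboxylic acid on this carbonyl carbon would read remains open. The step from compound 1 to compound 2 cannot be read, as both ends sit at a limit: the limit of > 100000 nM in this assay, at which 2 of the 4 values shown sit.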